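Piperidine for piperazine on a quinazoline acrylamide chain

The source may hold more compounds than are shown below. What is called first, only, known or untested is meant among the compounds shown, and "the series" means these compounds.

Measured compounds:
- compound 1, `COc1cc2ncnc(N3CCc4ccccc43)c2cc1NC(=O)/C=C/CN1CCN(C)CC1`: 9180 nM
- compound 2, `COc1cc2ncnc(N3CCc4ccccc43)c2cc1NC(=O)/C=C/CN1CCC(CO)CC1`: 2650 nM
- compound 3, `CN1CCN(C/C=C/C(=O)Nc2cc3c(N4CCCc5ccccc54)ncnc3cc2O[C@@H]2CCOC2)CC1`: 9450 nM

Of the compounds shown here, three have been tested in a functional assay on PC-3 cells (Homo sapiens) for antiproliferative activity, read by MTT assay, with a stated time of 72 h; on this read-out higher numbers stand for weaker inhibition and lower numbers for stronger inhibition. Compound 1 and compound 2 share one core and differ in a single place: 4-(hydroxymethyl)piperidin-1-yl in place of 4-methylpiperazin-1-yl on a saturated chain carbon bound to a double-bonded chain carbon. In this assay that change gave a 3.5-fold lower number from compound 1 to compound 2 (0.54 log units; beyond the scatter). Compound 3 carries a different core; how the core of compound 3 differs from the core of compound 1 is not broken down here. In this assay compound 3 gives 9450 nM, and the gap between compound 3 and compound 1 lies within the scatter, so no order between them is claimed.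

Compound 4, `O=C(/C=C/CN1CCC(CO)CC1)Nc1cc2c(N3CCCc4ccccc43)ncnc2cc1O[C@@H]1CCOC1`, has not yet been measured. It relates to compound 3 as compound 2 relates to compound 1: 4-(hydroxymethyl)piperidin-1-yl in place of 4-methylpiperazin-1-yl on a saturated chain carbon bound to a double-bonded chain carbon. The place described for this change is the same in both pairs, so it is the same kind of change made on a different core. For the measured compounds named here, since only one measured instance of the change exists, the expectation rests entirely on compound 1 and compound 2 and on a 3.5-fold lower number from compound 1 to compound 2 (0.54 log units; beyond the scatter), with the starting point set by compound 3 at 9450 nM. Compound 4 is therefore expected to show a step of about a 3.2-fold lower number from compound 3 to compound 4 (0.50 log units; beyond the scatter) in this assay, similar in size to the earlier one. The estimate for compound 4 in this assay is 3000 nM, with a plausible range from 1200 nM to 7500 nM.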

Compound 4, half-maximal inhibitory concentration: 5460 nM
The estimate for compound 4 lay 1.8-fold (0.26 log units) below the measured number, and the stated range covers the measured number.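

In this assay, placing 4-(hydroxymethyl)piperidin-1-yl where 4-methylpiperazin-1-yl stood on the second core gave a 1.7-fold lower number from compound 3 to compound 4 (0.24 log units; within the scatter), so no order is claimed for this pair. Set beside the earlier step, this one cannot be told apart from it, and the series gives no sign that the size of the step depends on the core: the same change on two cores in this assay, a 3.5-fold lower number (0.54 log units; beyond the scatter) from compound 1 to compound 2 and a 1.7-fold lower number (0.24 log units; within the scatter) from compound 3 to compound 4, 2.0-fold (0.30 log units) apart, within the scatter of two such steps This agrees with one shared step size on both cores, but it does not prove that the gain seen on the first core carries over, as only the step on that core lies beyond the scatter and the comparison rests on just two pairs in a single assay.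

The compounds shown leave open whether the hydroxymethyl group itself matters, or whether a plain piperidine, a morpholine or a dimethylamino group on a saturated chain carbon bound to a double-bonded chain carbon would give similar steps on both cores. They also leave open whether the same exchange would behave alike on a third core, or in a cell line other than the one used here.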